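This account rests on a few compounds, and the source may have more. Where it says the series, first, only, none or still open, it means among the compounds named here.

Notes on the series. All members share the core of compound 1, `OCCCCNCc1nc2c(OCC3CCCCC3)cccc2[nH]1`, and differ only in the group carried on the amine nitrogen. In an assay on cells for inhibition of interleukin-5 receptor subunit alpha (Mus musculus), read by WST assay, with a stated time of 48 h, tested at 30 uM, in the presence of a further agent that is not named here (a higher number here means more inhibition at the concentration tested (going by the name of the read-out), a lower number less inhibition), compound 1 gives 44.3%. Compound 2, `OCCCCCNCc1nc2c(OCC3CCCCC3)cccc2[nH]1`, gives 23.7%. The step between them, a number 20.6 percentage points lower from compound 1 to compound 2 (beyond the scatter), lies beyond the scatter. Compound 3, `CC(C)(CO)NCc1nc2c(OCC3CCCCC3)cccc2[nH]1`, gives 54.7% and stands highest of the three measured numbers, with compound 1 nearest and compound 2 furthest; both steps up to it, a number 10.4 percentage points higher from compound 1 to compound 3 (beyond the scatter) and a number 31 percentage points higher from compound 2 to compound 3 (beyond the scatter), are beyond the scatter.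

Compound 4, `c1ccc(NCc2nc3c(OCC4CCCCC4)cccc3[nH]2)cc1`, is next to be measured. Relative to compound 3 the change is phenyl in place of 1-(hydroxymethyl)-1-methylethyl on an amine nitrogen. Within the data shown here, none of the measured steps matches this change: each of them exchanges one hydroxy-bearing group for another, whereas here a phenyl group enters and the hydroxy group leaves. Among the measured compounds shown here, the measured steps therefore give no direct guide; they show only that varying the group on the amine nitrogen moves the read-out by modest to large amounts in either direction. An estimate for compound 4 is accordingly placed near the middle of the measured range, around 35%, spanning 10% to 60%. The step this estimate implies, a number 19.7 percentage points lower from compound 3 to compound 4 (beyond the scatter), is expected to be downward but remains uncertain in size.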

Compound 4, a percentage reported as inhibition, at one concentration (the size of the read-out at that concentration, not a potency): 25%
Compound 4: the middle estimate sits 10 percentage points above what was measured; the measured number falls inside the stated range.
By their numbers in this assay, from the lowest: compounds 2 and 4 (each within the scatter of the next); then compound 1; then compound 3.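

Phenyl on the amine nitrogen removes the hydroxy group altogether, and in this assay this costs inhibition against two of the hydroxy-bearing groups: a number 29.7 percentage points lower from compound 3 to compound 4 (beyond the scatter) and a number 19.3 percentage points lower from compound 1 to compound 4 (beyond the scatter). Against 5-hydroxypentyl there is no separation, a number 1.3 percentage points higher from compound 2 to compound 4 (within the scatter), so a group with no hydrogen-bond donor or acceptor, carrying a six-membered aromatic ring, reads alike with the longest hydroxy chain in the set, and a hydroxy group on this nitrogen does not by itself set the level of inhibition. No measurement bearing on the reason for these steps is at hand.

Phenyl differs from the hydroxy-bearing groups both in having a ring and in lacking the hydroxy group, so the compounds shown do not separate these two changes; a hydroxyphenyl group, a cyclohexyl group or a plain butyl chain on the same nitrogen would address that. Also open, from the compounds shown here alone, is whether the hydroxy group of the chains can be exchanged for another end group, such as an amine or a carboxylic acid, and how such a group would compare with compound 3.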